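The source may report more compounds than this note shows. Statements on the series, on what has been measured and on what is new or still open speak of the compounds shown alone.

Measured compounds:
Compound 1, `Cc1nnc(SCC(=O)N/N=c2/scc(-c3ccccc3)n2-c2ccccc2)s1`: 59.2%
Compound 2, `O=C(CSc1nnnn1-c1ccccc1)N/N=c1/scc(-c2ccc(Br)cc2)n1-c1ccccc1`: 20.4%
Compound 3, `Cc1nnc(SCC(=O)N/N=c2/scc(-c3ccc(F)cc3)n2-c2ccccc2)s1`: 26.5%

In a functional assay on C6 cells (Rattus norvegicus) for cytotoxicity, read by MTT assay, with a stated time of 24 h, tested at 200 ug/mL (on this read-out lower numbers stand for a stronger effect and higher numbers for a weaker effect at the one concentration tested), compound 2 gives 20.4%, the smallest number of the three. Its gap to compound 3 is within the usual scatter, so the two cannot be told apart; compound 1 lies beyond the scatter on the higher side, meaning a weaker effect. Going by the values given here, the only one-place step among the measured compounds is a number 32.7 percentage points lower from compound 1 to compound 3 (beyond the scatter), a change on the same phenyl ring but of a different kind.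

Compound 4, `Cc1ccc(-c2cs/c(=N/NC(=O)CSc3nnnn3-c3ccccc3)n2-c2ccccc2)cc1`, differs from compound 2 in one place: methyl in place of bromo on an aromatic carbon. Among the compounds with values here, no measured pair shows a bromo-to-methyl exchange, so the single measured step gives no direct guide to its size or direction. In this situation the expected outcome is that compound 4 stays close to compound 2, with no step beyond the scatter, and the estimated step is a number 5.6 percentage points higher from compound 2 to compound 4 (within the scatter). Compound 4 is therefore expected to give about 26%, within a range from 10% to 48% in this assay.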

Compound 4, a percentage reported as activity, at one concentration (the size of the read-out at that concentration, not a potency): 22.2%
Compound 4: middle estimate off by 3.8 percentage points, on the high side, within the range that was stated.
By their numbers in this assay, from the lowest: compounds 2, 4 and 3 (each within the scatter of the next); then compound 1.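

In this assay, the exchange of 4-bromophenyl to 4-methylphenyl gives a number 1.8 percentage points higher from compound 2 to compound 4 (within the scatter) and so leaves no readable difference between these two groups at this place on the ring, para to a large group. Going by these compounds alone, the earlier step (a number 32.7 percentage points lower from compound 1 to compound 3 (beyond the scatter)) concerned only fluoro in place of hydrogen, whereas this pair is the first to exchange one group for another at such a place, and bromo and methyl cannot be told apart here. Nothing measured here explains why these two groups read alike.

Going by these compounds, it remains open whether hydrogen at this place would read differently alongside the rest of compound 2. On these data alone, it also remains open whether a larger or very different group, such as an amine or a carboxylic acid, would give a number close to those of compound 2 and compound 4.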